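The source may hold more compounds than are shown below. What is called first, only, known or untested is meant among the compounds shown, and "the series" means these compounds.

Measured so far:
compound 1, `COc1ccc(/C=N/NC(=O)Nc2ccc(Br)cc2)cc1OC` — 300 mg/kg
compound 2, `C/C(=N\NC(=O)Nc1ccc(Br)cc1)c1ccc(N)cc1` — 300 mg/kg
compound 3, `CNC(=S)Nc1ccc(S(=O)(=O)Nc2nc3ccc(F)cc3s2)cc1` — 300 mg/kg

All three compounds were tested in a functional assay on the whole organism with Mus musculus as the target, in the maximal electroshock model, with a stated time of 0.5 h; on this read-out lower numbers stand for an effect already at smaller amounts and higher numbers for an effect only at larger amounts of compound. Compound 1 gives 300 mg/kg, compound 2 gives 300 mg/kg, and compound 3 gives 300 mg/kg. On these numbers compound 3 stands level with compounds 1 and 2: its nearest neighbour is compound 1, with no change at the digits shown, and its furthest is compound 2, again with no change at the digits shown, so nothing among the three separates from the rest beyond the usual scatter of this kind of measurement.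

The next compound, compound 4, `CCNC(=S)Nc1ccc(S(=O)(=O)Nc2nc3ccc(F)cc3s2)cc1`, follows from compound 3 by a single alteration: methyl in place of hydrogen on a saturated chain carbon bound to an amide-type nitrogen. Read one bond further out, the methylamino group of compound 3 becomes an ethylamino group in compound 4.

Within the data shown here, no pair of measured compounds differs in only one place, so the data offer no step of this kind to lean on. Given that compound 3 sits at 300 mg/kg alongside the two others, the expectation for compound 4 is a step of no change at the digits printed from compound 3 to compound 4 (within the scatter), that is, no movement beyond the scatter in either direction. Compound 4 is therefore estimated at 300 mg/kg, with a range from 100 mg/kg to 600 mg/kg.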

Compound 4, minimum effective dose: 300 mg/kg
The estimate for compound 4 equals the measured number at the digits printed; the measured number falls inside the stated range.
By their numbers in this assay, from the lowest: compounds 1, 2, 3 and 4 (each within the scatter of the next).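

In this assay, among these compounds, the step from methylamino to ethylamino reads no change at the digits printed from compound 3 to compound 4 (within the scatter) and gives the first comparison of two compounds that differ in one place. The earlier compounds shown here offered only values standing level, with no link between any of those values and a single place in the structure, whereas this pair shows that methyl in place of hydrogen on a saturated chain carbon bound to an amide-type nitrogen brings no movement beyond the scatter. Nothing at hand offers an explanation for this flat step.

The compounds shown leave open whether the read-out would stay level with a longer chain such as propyl or butyl, with a branched group such as isopropyl, or with a chain ending in an amine or a carboxylic acid at this position. They also leave open whether any change in this place can move the minimum effective dose in either direction, and whether methyl in place of hydrogen would read the same on the core of compound 1.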